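This account rests on a few compounds, and the source may have more. Where it says the series, first, only, none or still open, it means among the compounds named here.

Measured compounds in an ADME assay for pharmacokinetics, read by LC-MS, in phosphate buffer, with a stated time of 120 min, at pH 7.4, tested at 1 uM, in the presence of a further agent that is not named here; a lower number here means that the compound disappears faster, a higher number that the compound lasts longer:
- compound 1, `C=C(CO)C(=O)Nc1ccccc1`: > 8.53 h
- compound 2, `C=C(Cl)C(=O)Nc1ccccc1`: 0.05 h
- compound 3, `C=C(C)C(=O)Nc1ccccc1`: > 8.53 h

Compound 3 gives only a limit, > 8.53 h, so its place is known only as a floor. Compound 1 likewise gives a limit, > 8.53 h; two of the three values sit there (the limit of > 8.53 h in this assay, at which 2 of the 3 values shown sit). Compound 2 gives a number, 0.05 h, and the step of an at least 170-fold higher number from compound 2 to compound 3 (2.23 log units; beyond the scatter) is large, as is an at least 170-fold lower number from compound 1 to compound 2 (2.23 log units; beyond the scatter); the step that the two limits leave unreadable from compound 1 to compound 3 cannot be read.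

Compound 4, `C=C(C(=O)Nc1ccccc1)C(F)(F)F`, differs from compound 3 by trifluoromethyl in place of methyl on a double-bonded chain carbon bound to a carbonyl carbon. The measured steps at this position, an at least 170-fold lower number from compound 1 to compound 2 (2.23 log units; beyond the scatter) and an at least 170-fold higher number from compound 2 to compound 3 (2.23 log units; beyond the scatter), show that substitution there can move this assay far in either direction. A large downward step is expected, toward the value of compound 2. The expected step is an at least 28-fold lower number from compound 3 to compound 4 (1.45 log units; beyond the scatter). Compound 4 is estimated at 0.3 h, within 0.03 h to 5 h.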

Compound 4, half-life: 0.25 h
The estimate for compound 4 lay 1.2-fold (0.08 log units) above the measured number; the range from low to high includes it.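

In this assay, trifluoromethyl on the double-bonded chain carbon bound to a carbonyl carbon joins chloro on the fast-disappearing side, with an at least 34-fold lower number from compound 3 to compound 4 (1.53 log units; beyond the scatter) and an at least 34-fold lower number from compound 1 to compound 4 (1.53 log units; beyond the scatter). It is not equivalent to chloro, however, as a 5.0-fold higher number from compound 2 to compound 4 (0.70 log units; beyond the scatter) shows that this position separates these two groups beyond the scatter. The steps from compound 1 and compound 3 are only minimum sizes, resting on a limit: the limit of > 8.53 h in this assay, at which 2 of the 4 values shown sit.

On these data alone, how far compound 1 and compound 3 lie beyond that limit stays open. So does whether a nitrile or an amine at this place would fall with chloro and trifluoromethyl or with methyl and hydroxymethyl.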